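A Methoxy Group Added to Compound 2

The source may hold more compounds than are shown below. What is called first, only, known or untested is meant among the compounds shown, and "the series" means these compounds.

In a physicochemical assay for lipophilicity, read by HPLC (on this read-out higher numbers stand for higher lipophilicity and lower numbers for lower lipophilicity), compound 1 (`CC(=O)NC[C@H]1CN(c2ccc(OC[C@@H](O)CNc3ccncc3)c(F)c2)C(=O)O1`) gives -0.04 and compound 2 (`CC(=O)NC[C@H]1CN(c2ccc(OC[C@H]3CN(c4ccccc4)C(=O)O3)c(F)c2)C(=O)O1`) gives 1.86 as the higher of the two numbers, a gap beyond the scatter. Compound 3 (`COc1ccc(N2C[C@H](COc3ccc(N4C[C@H](CNC(C)=O)OC4=O)cc3F)OC2=O)cc1`) departs from compound 2 with methoxy in place of hydrogen on an aromatic carbon, para to a large group (methoxy in place of hydrogen on an aromatic carbon). Among the compounds with values here, no measured pair shows this change directly. In this assay no step beyond the scatter is expected, and the estimated change is a number 0.04 log units higher from compound 2 to compound 3 (within the scatter) in size. Compound 3 is expected at 1.9 with an estimated range of 1.55 to 2.25 around it.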

Compound 3, partition coefficient: 1.73
Beside the measured number, compound 3's estimate is 0.17 log units above it; low and high end bracket the measured number.
By their numbers in this assay, from the lowest: compound 1; then compounds 3 and 2 (each within the scatter of the next).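

Within the data shown here, this pair gives the first direct reading of phenyl to 4-methoxyphenyl: in this assay, methoxy in place of hydrogen on this aromatic carbon, para to a large group, gives a number 0.13 log units lower from compound 2 to compound 3 (within the scatter). At this position, then, the change leaves the two compounds indistinguishable on this read-out. Nothing available accounts for this result.

The compounds shown leave open whether an amine, a carboxylic acid or a longer chain such as ethoxy at this position would also remain within the scatter. They also leave open how methoxy would read on another carbon of this ring.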